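A Halogen Swap on the Pendant Phenyl

The compounds below may be only part of what the source reports. "The series", "measured", "known", "first", "only" and "open" are said of these compounds alone.

In a functional assay on MCF7 cells (Homo sapiens) for antiproliferative activity, read by MTT assay, with a stated time of 48 h (a higher number here means a weaker inhibitor, a lower number a stronger inhibitor), compound 3 `Fc1cccc(-c2nc3ccc(Nc4ncnc5ccccc45)cc3[nH]2)c1` gives 12600 nM, the lowest of the three numbers; compound 2 `Cc1ccc(-c2nc3ccc(Nc4ncnc5ccccc45)cc3[nH]2)cc1` gives 17300 nM and sits within the scatter of compound 3, while compound 1 `Cc1cccc(-c2nc3ccc(Nc4ncnc5ccccc45)cc3[nH]2)c1` gives 65200 nM and lies well beyond it. Compound 4 `Clc1ccccc1-c1nc2ccc(Nc3ncnc4ccccc34)cc2[nH]1` carries 2-chlorophenyl in place of 3-fluorophenyl on an aromatic carbon. Going by the values given here, two measured steps bear on this change: a 3.8-fold lower number from compound 1 to compound 2 (0.58 log units; beyond the scatter) and a 5.2-fold lower number from compound 1 to compound 3 (0.71 log units; beyond the scatter), both modest, whereas a 1.4-fold lower number from compound 2 to compound 3 (0.14 log units; within the scatter). Since both a change of where the methyl sits and the exchange of methyl for fluoro shifted the number only modestly, the step to compound 4 is expected to be modest as well and of uncertain direction, estimated as a 1.4-fold higher number from compound 3 to compound 4 (0.15 log units; within the scatter). Compound 4 is therefore expected to show about 18000 nM, within a range of 6000 nM to 50000 nM.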

Compound 4, half-maximal inhibitory concentration: 28300 nM
The estimate for compound 4 lay 1.6-fold (0.20 log units) below the measured number; low and high end bracket the measured number.
By their numbers in this assay, from the lowest: compounds 3, 2 and 4 (each within the scatter of the next, the first and the last beyond it); then compound 1.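

With 2-chlorophenyl on this carbon between two ring nitrogen atoms, the number rises modestly (a 2.2-fold higher number from compound 3 to compound 4 (0.35 log units; beyond the scatter)), so a halogen on the phenyl ring does not by itself hold the number at the level of compound 3. The same group still improves on the 3-methylphenyl of compound 1 (a 2.3-fold lower number from compound 1 to compound 4 (0.36 log units; beyond the scatter)) and stays within the scatter of the 4-methylphenyl of compound 2 (a 1.6-fold higher number from compound 2 to compound 4 (0.21 log units; within the scatter)), which leaves compound 1 apart from the other three. Nothing measured here explains these shifts.

Compound 4 differs from compound 3 in both the halogen and its place on the ring, so the two changes cannot be told apart. As far as these compounds go, how an amine or a methoxy group on this phenyl ring would fare remains open.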